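Replacing the 6-hydroxyhexyl chain of compound 3

The source may hold more compounds than are shown below. What is called first, only, known or untested is meant among the compounds shown, and "the series" means these compounds.

- Compound 1 `CCCCOOC1(OOC)CCCCCCCCCCC1`: 20000 nM
- Compound 2 `COOC1(OOCCCc2ccccc2)CCCCCCCCCCC1`: 34000 nM
- Compound 3 `COOC1(OOCCCCCCO)CCCCCCCCCCC1`: 1600 nM
- Compound 4 `COOC1(OOCCC(=O)OC)CCCCCCCCCCC1`: not yet measured

In a functional assay on FM3A cells (Mus musculus) for cytotoxicity (on this read-out lower numbers stand for an effect already at smaller amounts and higher numbers for an effect only at larger amounts of compound), compound 3 has the lowest number of the three measured compounds. Its distance from the other two is large, with a 13-fold lower number from compound 1 to compound 3 (1.10 log units; beyond the scatter) and a 21-fold lower number from compound 2 to compound 3 (1.33 log units; beyond the scatter). By contrast, a 1.7-fold higher number from compound 1 to compound 2 (0.23 log units; within the scatter), which lies within the scatter.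

The next structure, compound 4, brings this change: methoxycarbonyl in place of 4-hydroxybutyl on a saturated chain carbon, two bonds along the chain from an oxygen. Cut one bond further out, the same difference reads 6-hydroxyhexyl to 2-(methoxycarbonyl)ethyl. Compound 3 alone among the measured compounds carries a hydroxyl group, and compound 4 has none. Within the data shown here, no measured compound carries an ester, so the two large steps offer only a loose guide. A move back toward higher numbers in this assay is expected, probably not the full distance. The expected change is a 5.0-fold higher number from compound 3 to compound 4 (0.70 log units; beyond the scatter). For compound 4 the estimated value is 8000 nM, with an expected range of 1800 nM to 32000 nM.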

Compound 4, half-maximal effective concentration: 1400 nM
Beside the measured number, compound 4's estimate is 5.7-fold (0.76 log units) above it; the whole stated range lies above it.
By their numbers in this assay, from the lowest: compounds 4 and 3 (each within the scatter of the next); then compounds 1 and 2 (each within the scatter of the next).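

In this assay, the step from the 4-hydroxybutyl to the methoxycarbonyl end of the chain stays within the scatter (a 1.1-fold lower number from compound 3 to compound 4 (0.06 log units; within the scatter)), so among these compounds a hydroxyl group on this chain is not required for a number in this low range. Compound 4 also keeps the large distance from the two compounds with plain hydrocarbon chain ends, with methoxycarbonyl in place of benzyl (a 24-fold lower number from compound 2 to compound 4 (1.39 log units; beyond the scatter)) and in place of ethyl (a 14-fold lower number from compound 1 to compound 4 (1.15 log units; beyond the scatter)). No supporting data are available to explain why the ester and the alcohol chains give such similar numbers.

From the compounds shown here alone, it remains open whether a carboxylic acid or an amine at the end of this chain would fall with compound 3 and compound 4 or with the other two. Also open, going by these compounds, is how a longer chain carrying the methyl ester would read in this assay.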